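This account rests on a few compounds, and the source may have more. Where it says the series, first, only, none or still open, it means among the compounds named here.

Measured so far in a functional assay on SW480 cells (Homo sapiens) for cytotoxicity, read by MTT assay, with a stated time of 48 h; a higher number here means a weaker inhibitor, a lower number a stronger inhibitor:
Compound 1 `O=c1ccoc2cc(OCc3cn(Cc4ccc(F)cc4)nn3)ccc12`: 11200 nM.
Compound 2 `N#Cc1cccc(Cn2cc(COc3ccc4c(=O)ccoc4c3)nn2)c1`: > 100000 nM, which is a limit of the assay and not a number.

Among the measured compounds shown here, compound 2 therefore sits at the limit of > 100000 nM in this assay, at which 1 of the 2 values shown sits, and carries no exact value; compound 1 supplies the only exact number. For the measured compounds named here, the one measured step, an at least 8.9-fold higher number from compound 1 to compound 2 (0.95 log units; beyond the scatter), shows that the aryl group on the saturated chain carbon bound to an aromatic nitrogen can move the read-out well beyond the scatter. Compound 3 `COc1ccc(Cn2cc(COc3ccc4c(=O)ccoc4c3)nn2)cc1` differs from compound 2 by 4-methoxyphenyl in place of 3-cyanophenyl on a saturated chain carbon bound to an aromatic nitrogen. Going by the values given here, no measured step covers 4-methoxyphenyl, and the single step at this position runs from a finite number into the limit, so its true size is unknown. Whether 4-methoxyphenyl lands nearer compound 1 or stays near compound 2 cannot be read from two points; the expected step is an at least 2.5-fold lower number from compound 2 to compound 3 (0.39 log units; beyond the scatter), with a real chance that only a limit is returned again. Compound 3 is estimated at 40000 nM, within the range 8000 nM to 150000 nM.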

Compound 3, half-maximal inhibitory concentration: 20400 nM
Beside the measured number, compound 3's estimate is 2.0-fold (0.29 log units) above it; the measured number falls inside the stated range.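

In this assay, the place on a saturated chain carbon bound to an aromatic nitrogen is not closed to finite read-outs: 4-methoxyphenyl in place of 3-cyanophenyl gives an at least 4.9-fold lower number from compound 2 to compound 3 (0.69 log units; beyond the scatter). The step for methoxy in place of fluoro on an aromatic carbon is a 1.8-fold higher number from compound 1 to compound 3 (0.26 log units; within the scatter), so this pair cannot be told apart in this read-out. Of the three groups at this place, only 3-cyanophenyl, in compound 2, gives a limit of the assay and not a number: the limit of > 100000 nM in this assay, at which 1 of the 3 values shown sits.

The compounds shown do not separate the nitrile from its place on the ring, a question on which a 4-cyanophenyl group would bear. Going by these compounds, how an amine such as 4-aminophenyl, or a longer chain such as phenethyl in place of 4-methoxybenzyl, would read here also stays open.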